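Chain extension on the acyl group of compound 3

The source may report more compounds than this note shows. Statements on the series, on what has been measured and on what is new or still open speak of the compounds shown alone.

Measured compounds:
compound 1, `CCC(=O)N1CCN(S(=O)(=O)c2ccccc2)CC1`: 0.1 mg/kg
compound 2, `CCC(=O)N1CCN(S(=O)(=O)c2ccc(C)cc2)CC1`: 10 mg/kg
compound 3, `CCC(=O)N1CCN(S(=O)(=O)c2ccc(F)cc2)CC1`: 0.01 mg/kg

In a functional assay on the whole organism with Mus musculus as the target (a higher number here means that more compound is needed for the effect, a lower number that less compound is needed), compound 3 gives the lowest number of the three. The nearest is compound 1, a 10-fold lower number from compound 1 to compound 3 (1.00 log units; beyond the scatter); the furthest is compound 2, a 1000-fold lower number from compound 2 to compound 3 (3.00 log units; beyond the scatter). Compound 4, `CCCC(=O)N1CCN(S(=O)(=O)c2ccc(F)cc2)CC1`, differs from compound 3 by methyl in place of hydrogen on a saturated chain carbon, two bonds along the chain from a carbonyl carbon. The measured steps all concern the aromatic carbon, a 100-fold higher number from compound 1 to compound 2 (2.00 log units; beyond the scatter) and a 10-fold lower number from compound 1 to compound 3 (1.00 log units; beyond the scatter), and none alters the acyl chain, so they give no direct guidance here. For the measured compounds named here, with no comparable step in hand, the expectation for this assay is a change no larger than the scatter, no change at the digits printed from compound 3 to compound 4 (within the scatter). Compound 4 is accordingly estimated at 0.01 mg/kg, with a range from 0.003 mg/kg to 0.05 mg/kg.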

Compound 4, minimum effective dose: > 10 mg/kg
Compound 4 was reported as a limit (the forecaster's own chance of this, stated with the estimate: 5%); at least 1000-fold (3.00 log units) between middle value and limit.
By their numbers in this assay, from the lowest: compound 3; then compound 1; then compound 2.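

For the compounds shown here, the acyl chain, untouched by the earlier compounds, proves highly sensitive in this assay: methyl in place of hydrogen on the saturated chain carbon, two bonds along the chain from a carbonyl carbon, gives an at least 1000-fold higher number from compound 3 to compound 4 (3.00 log units; beyond the scatter). Compound 4 stands as a limit, > 10 mg/kg, so the size of this step is a bound and not a measured difference: the limit of > 10 mg/kg in this assay, at which 1 of the 4 values shown sits. The methyl on the aromatic carbon moves the number the same way, a 100-fold higher number from compound 1 to compound 2 (2.00 log units; beyond the scatter).

As far as these compounds go, whether an acetyl group, a longer chain or a branched acyl chain keeps the low dose remains open. Also open, from the compounds shown here alone, is whether the same chain change has a like effect on compound 1.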